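A few compounds are considered here, and "the series" means these few. Any claim that something is new, unique, unknown or untested is made for them only; others in the source may bear on it.

Working notes on the series. Among the measured compounds shown here, in a functional assay on THP-1 cells (Homo sapiens) for inhibition (on this read-out lower numbers stand for stronger inhibition and higher numbers for weaker inhibition), compound 3 `C[C@H](NC(=O)C(=O)Nc1ccccc1Br)C(=O)N[C@@H](CC(=O)O)C(=O)COc1c(F)c(F)cc(F)c1F` gives 50 nM, the lowest of the three numbers measured so far. Compound 1 `C[C@H](NC(=O)C(=O)Nc1ccccn1)C(=O)N[C@@H](CC(=O)O)C(=O)COc1c(F)c(F)cc(F)c1F` gives 200 nM and compound 2 `C[C@H](NC(=O)C(=O)NCc1ccccc1)C(=O)N[C@@H](CC(=O)O)C(=O)COc1c(F)c(F)cc(F)c1F` gives 160 nM. The steps of a 4.0-fold lower number from compound 1 to compound 3 (0.60 log units; beyond the scatter) and a 3.2-fold lower number from compound 2 to compound 3 (0.51 log units; beyond the scatter) both lie beyond the scatter, whereas a 1.3-fold lower number from compound 1 to compound 2 (0.10 log units; within the scatter) stays within it.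

Compound 4 `C[C@H](NC(=O)C(=O)Nc1ccccc1Oc1ccccc1)C(=O)N[C@@H](CC(=O)O)C(=O)COc1c(F)c(F)cc(F)c1F` differs from compound 3 by phenoxy in place of bromo on an aromatic carbon. For the measured compounds named here, the steps that bear on this change are the two that lead into compound 3: they show that 2-bromophenyl on the amide-type nitrogen gives a lower number than pyridin-2-yl or benzyl, but no measured pair exchanges one group on that ring for another, so the size of the coming step has no direct anchor. The expectation is therefore a small step, a 1.2-fold higher number from compound 3 to compound 4 (0.08 log units; within the scatter), not clearly beyond the scatter in either direction, with the range kept wide on both sides. Compound 4 is expected to give 60 nM in this assay, between 20 nM and 200 nM.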

Compound 4, half-maximal inhibitory concentration: 800 nM
Compound 4: the middle estimate sits 13-fold (1.12 log units) below what was measured; measured number outside the range, above it.
By their numbers in this assay, from the lowest: compound 3; then compounds 2 and 1 (each within the scatter of the next); then compound 4.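

In this assay, among the compounds shown here, the place on the aromatic ring that carries bromo in compound 3 is not neutral to exchange, which the earlier steps, all made on the amide-type nitrogen, could not show. Phenoxy in place of bromo gives a 16-fold higher number from compound 3 to compound 4 (1.20 log units; beyond the scatter), so the 2-bromophenyl group's advantage does not carry over to a larger group at this place, ortho to a large group. No measurement bears on the cause of this loss of inhibition.

On these data alone, with one exchange at this place, it remains open whether the higher number follows the added aromatic ring, the oxygen that links it, or simply the larger group. Smaller groups such as chloro, methyl or methoxy, or an amine, would show whether bromo is a special case or one point on a wider trend.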